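Piperidine ether series: ethoxy(phenyl)methyl variant of compound 2

The compounds below may be only part of what the source reports. "The series", "measured", "known", "first", "only" and "open" are said of these compounds alone.

Measured so far:
compound 1, `COc1cc2nc(N3CCC(OCCOC(C)C)CC3)nc(N)c2cc1OC`, 0.67 nM
compound 2, `COc1cc2nc(N3CCC(OCC(C)OC)CC3)nc(N)c2cc1OC`, 1.41 nM

Both numbers come from an assay on brain for displacement of a labelled ligand from Adrenergic receptor alpha-1 (Rattus norvegicus); a lower number here means a stronger inhibitor, a higher number a weaker inhibitor. Within the data shown here, compound 2 holds the higher of the two numbers, its only neighbour being compound 1, from which it is separated by a 2.1-fold higher number from compound 1 to compound 2 (0.32 log units; beyond the scatter).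

Compound 3, `CCOC(COC1CCN(c2nc(N)c3cc(OC)c(OC)cc3n2)CC1)c1ccccc1`, is not yet measured. It differs from compound 2 in one place: ethoxy(phenyl)methyl in place of 1-methoxyethyl on a saturated chain carbon bound to an oxygen on a saturated carbon.

Among the measured compounds shown here, the one step known so far swaps small ether fragments and was modest, whereas this change brings in an aromatic ring on the same chain carbon; no measured pair shows a change of this kind, so the prior is weak. For the measured compounds named here, the single related step suggests the chain end tolerates variation within a modest span, and a step of about a 1.1-fold higher number from compound 2 to compound 3 (0.03 log units; within the scatter) is expected, in either direction plausible, with a wider range than usual. Compound 3 is therefore estimated at 1.5 nM, within 0.4 nM to 6 nM.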

Compound 3, inhibition constant: 0.52 nM
Estimate against measurement, compound 3: 2.9-fold (0.46 log units) above; low and high end bracket the measured number.
By their numbers in this assay, from the lowest: compounds 3 and 1 (each within the scatter of the next); then compound 2.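

In this assay, ethoxy(phenyl)methyl in place of 1-methoxyethyl on a saturated chain carbon bound to an oxygen on a saturated carbon gives a 2.7-fold lower number from compound 2 to compound 3 (0.43 log units; beyond the scatter), so this place accepts a six-membered aromatic ring of carbon only and 10 heavy atoms instead of 4 without a rise in the number. The step of a 1.3-fold lower number from compound 1 to compound 3 (0.11 log units; within the scatter) leaves the aromatic group and isopropoxymethyl level in this assay, so the ring is tolerated here but gives no separation from that open-chain ether. No measurement shown bears on why the number moves with this change.

Open, on these data alone, is whether the phenyl ring or the ethoxy part of the new group accounts for the step from compound 2. Every group shown holds an ether oxygen, so an amine, a carboxylic acid or a longer alkyl chain without that oxygen remains unplaced.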